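The source may hold more compounds than are shown below. What is called first, only, known or untested is meant among the compounds shown, and "the series" means these compounds.

Measured compounds:
compound 1 `COc1cc(-c2cc(/C=C/C(=O)c3ccc(N)cc3)[nH]n2)cc(OC)c1OC` — 29%
compound 2 `COc1ccc(-c2cc(/C=C/C(=O)c3cc(OC)c(OC)c(OC)c3)[nH]n2)cc1OC` — 9%
compound 3 `COc1ccc(C(=O)/C=C/c2cc(-c3cc(OC)c(OC)c(OC)c3)n[nH]2)cc1` — 13%

In a functional assay on Hs-578T cells (Homo sapiens) for cytotoxicity, read by sulforhodamine B assay, with a stated time of 48 h, tested at 10 uM (on this read-out lower numbers stand for a stronger effect and higher numbers for a weaker effect at the one concentration tested), compound 3 stands second highest of the three numbers. Its nearest neighbour is compound 2, whose value lies within the scatter of that of compound 3. Among the measured compounds shown here, its furthest is compound 1, separated by a number 16 percentage points lower from compound 1 to compound 3 (beyond the scatter), the only step in the set at the aryl on the carbonyl carbon.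

Compound 4 `COc1cc(-c2cc(/C=C/C(=O)c3ccc(F)c(F)c3)[nH]n2)cc(OC)c1OC` differs from compound 3 by 3,4-difluorophenyl in place of 4-methoxyphenyl on a carbonyl carbon. For the measured compounds named here, no measured step involves a difluorophenyl or a change at this position other than the amino to methoxy one, so the step from compound 1 to compound 3 is the only guide. With a modest basis, a step of a number 5 percentage points higher from compound 3 to compound 4 (within the scatter) is expected, not clearly beyond the scatter.

Compound 4 is therefore estimated at 18%, within 5% to 40%.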

Compound 4, a percentage reported as activity, at one concentration (the size of the read-out at that concentration, not a potency): 21%
Beside the measured number, compound 4's estimate is 3 percentage points below it; measured number inside the range.
By their numbers in this assay, from the lowest: compounds 2, 3, 4 and 1 (each within the scatter of the next, the first and the last beyond it).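

In this assay the 3,4-difluorophenyl on the carbonyl carbon sits level with both earlier aryl groups: a number 8 percentage points higher from compound 3 to compound 4 (within the scatter) and a number 8 percentage points lower from compound 1 to compound 4 (within the scatter). The position thus accepts an aryl with fluorine in place of methoxy or amino without a step beyond the scatter, even though the other two aryl groups are separated by a number 16 percentage points lower from compound 1 to compound 3 (beyond the scatter). No supporting data bear on the cause of these values.

Open, as far as these compounds go, is whether a carboxylic acid or a longer chain at this carbonyl carbon would move the number beyond the scatter. Also open, from the compounds shown here alone, is whether the 3,4-difluorophenyl would behave the same on the core of compound 2.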